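Chain extension on the hydrazone of compound 1

The source may hold more compounds than are shown below. What is called first, only, known or untested is meant among the compounds shown, and "the series" means these compounds.

Compound 1 `CC/C(C)=N\Nc1nc(-c2cccc([N+](=O)[O-])c2)cs1` gives 1650000 nM in a functional assay, with a stated time of 90 min (on this read-out higher numbers stand for an effect only at larger amounts of compound and lower numbers for an effect already at smaller amounts), the highest of the three numbers, though compound 2 `CCCC/C(C)=N\Nc1nc(-c2cccc([N+](=O)[O-])c2)cs1` with 1460000 nM and compound 3 `CCCC/C(CC)=N\Nc1nc(-c2cccc([N+](=O)[O-])c2)cs1` with 1560000 nM both sit within the scatter of it. Compound 4 `CCCCCC/C(C)=N\Nc1nc(-c2cccc([N+](=O)[O-])c2)cs1` differs from compound 1 by butyl in place of hydrogen on a saturated chain carbon, two bonds along the chain from a carbon with a double bond to nitrogen. The step of a 1.1-fold lower number from compound 1 to compound 2 (0.05 log units; within the scatter) adds ethyl on a saturated chain carbon, two bonds along the chain from a carbon with a double bond to nitrogen, and the step of a 1.1-fold higher number from compound 2 to compound 3 (0.03 log units; within the scatter) adds methyl on a saturated chain carbon bound to a carbon with a double bond to nitrogen; neither moved the read-out. No shift in this assay beyond the scatter is therefore expected, the expected step being a 1.1-fold lower number from compound 1 to compound 4 (0.04 log units; within the scatter). Compound 4 is expected to give 1500000 nM in this assay, within 700000 nM to 3500000 nM.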

Compound 4, half-maximal effective concentration: 1240000 nM
For compound 4 the middle estimate is 1.2-fold (0.08 log units) above the measured one, within the range that was stated.
By their numbers in this assay, from the lowest: compounds 4, 2, 3 and 1 (each within the scatter of the next).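

Butyl in place of hydrogen at this position extends the range of additions tested in this assay beyond the ethyl of compound 2, and the result, a 1.3-fold lower number from compound 1 to compound 4 (0.12 log units; within the scatter), still shows no shift beyond the scatter. Ethyl in place of hydrogen on a saturated chain carbon, four bonds along the chain from a carbon with a double bond to nitrogen, likewise gives no such shift, with a 1.2-fold lower number from compound 2 to compound 4 (0.07 log units; within the scatter). From the compounds shown here alone, whether an amine or a carboxylic acid in place of butyl would move this read-out stays open. No available evidence bears on why the read-out stays within the scatter.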